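The source may report more compounds than this note shows. Statements on the series, on what has been measured and on what is new or still open speak of the compounds shown alone.

Of the compounds shown here, three sharing one core have so far been measured in a physicochemical assay for solubility, at pH 2; a higher number here means a more soluble compound, a lower number a less soluble compound. Compound 1 `CNc1nc(NCCCN(C)C)c2sc(-c3ccc(-n4cccn4)cc3)cc2n1` gives 217 ug/mL in this assay, and compound 3 `CNc1nc(NCCCN(C)C)c2sc(-c3cccc(C(F)(F)F)c3)cc2n1` gives 180 ug/mL. For compound 2 `CNc1nc(NCCCN(C)C)c2sc(-c3ccc(N)cc3)cc2n1` this assay reports only a limit, > 100 ug/mL, so where compound 2 truly stands on the solubility scale is not known beyond that limit. For the measured compounds named here, the single step that touches compound 2, a step that the limit leaves unreadable from compound 1 to compound 2, cannot be sized because compound 2 sits at the limit of > 100 ug/mL in this assay, at which 1 of the 3 values shown sits; its direction, if any, is not readable.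

Compound 4 `CNc1nc(NCCCN(C)C)c2sc(-c3ccoc3)cc2n1` has not yet been measured in this assay. It differs from compound 2 by furan-3-yl in place of 4-aminophenyl on an aromatic carbon. Going by the values given here, no measured step in this assay involves either a furan-3-yl group or the loss of a 4-aminophenyl group, so the change has no direct precedent here; the only guidance is that compound 1 and compound 3, which carry other aromatic groups at the same place, both lie well within the measurable range and within the usual scatter of each other.

On that basis compound 4 is expected to give about 200 ug/mL in this assay, plausibly between 80 ug/mL and 450 ug/mL. The step that the limit leaves unreadable from compound 2 to compound 4 is thus estimated to leave compound 4 on the soluble side, although a limit rather than a number remains possible.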

Compound 4, solubility: 221 ug/mL
For compound 4 the middle estimate is 1.1-fold (0.04 log units) below the measured one, within the range that was stated.
By their numbers in this assay, from the lowest: compounds 3, 1 and 4 (each within the scatter of the next).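

No new step can be read from these results: compound 4 can be compared only with compound 2, and in this assay that step cannot be sized because compound 2 is reported only as a limit: the limit of > 100 ug/mL in this assay, at which 1 of the 4 values shown sits.

The compounds shown leave open where compound 2 truly stands, and so whether furan-3-yl in place of 4-aminophenyl changes the read-out at all.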